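A few compounds are considered here, and "the series" means these few. Any claim that something is new, unique, unknown or untested is made for them only; others in the source may bear on it.

Values in a functional assay on Molt4/C8 cells (Homo sapiens) for cytotoxicity; on this read-out lower numbers stand for stronger inhibition and higher numbers for weaker inhibition:
- compound 1 `O=C(/C=C/C(=O)N1C/C(=C\c2ccccc2)C(=O)/C(=C/c2ccccc2)C1)Nc1ccc(Cl)c(Cl)c1`: 1700 nM
- compound 2 `Cc1ccc(NC(=O)/C=C/C(=O)N2C/C(=C\c3ccccc3)C(=O)/C(=C/c3ccccc3)C2)cc1C`: 7900 nM
- compound 3 `O=C(/C=C/C(=O)N1C/C(=C\c2ccccc2)C(=O)/C(=C/c2ccccc2)C1)Nc1ccccc1`: not yet measured

Of the two measured compounds, compound 2 has the higher number, at 7900 nM. The next change is phenyl in place of 3,4-dimethylphenyl on an amide-type nitrogen. For the measured compounds named here, only one measured step bears on it: a 4.6-fold higher number from compound 1 to compound 2 (0.67 log units; beyond the scatter), with 3,4-dimethylphenyl in place of 3,4-dichlorophenyl on that nitrogen. That step is modest and compares two substituted rings, so it guides size only loosely. The expected step is a 1.6-fold lower number from compound 2 to compound 3 (0.20 log units; within the scatter), smaller than the measured one and towards a lower number. Compound 3 is estimated at 5000 nM, with an expected range of 1800 nM to 14000 nM.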

Compound 3, half-maximal inhibitory concentration: 520 nM
Compound 3: middle estimate off by 9.6-fold (0.98 log units), on the high side; the measured number lies below the stated range.
By their numbers in this assay, from the lowest: compound 3; then compound 1; then compound 2.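

In this assay, phenyl on the amide-type nitrogen gives a lower number than either substituted ring, with a 15-fold lower number from compound 2 to compound 3 (1.18 log units; beyond the scatter) and a 3.3-fold lower number from compound 1 to compound 3 (0.51 log units; beyond the scatter). The earlier step compared only 3,4-dichlorophenyl with 3,4-dimethylphenyl, whereas these steps show that both substituted rings stand above the plain ring, the 3,4-dimethylphenyl by the larger margin. No supporting data accompany this order. Still open, from the compounds shown here alone, is whether a single methyl or a single chlorine already raises the number. A ring carrying a methoxy group or an amine also remains to be placed in this order.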